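The compounds below may be only part of what the source reports. "The series", "measured", "known", "first", "only" and "open" are said of these compounds alone.

Series notes. Compound 1 `Nc1ccc(CN2N=C(c3ccc(F)cc3)C3C=CC=CC3C2=O)cc1` carries a free amine on a ring nitrogen-bearing position of the shared core. In an ADME assay on Huh-7 cells (Homo sapiens) for cytotoxicity, read by MTT assay, with a stated time of 48 h (on this read-out lower numbers stand for higher toxicity in this test and higher numbers for lower toxicity in this test), compound 1 gives only a limit, > 80000 nM. Compound 2 `CN(C)CCCCC(=O)Nc1ccc(CN2N=C(c3ccc(F)cc3)C3C=CC=CC3C2=O)cc1` is the acylated variant, and in this assay compound 2 gives 77700 nM. Within the data shown here, the one measured step, an at least 1.0-fold lower number from compound 1 to compound 2 (0.01 log units; that floor lies within the scatter), brings (4-(dimethylamino)butyl)carbonyl in place of hydrogen on a nitrogen on an aromatic ring; it is bounded by the limit of > 80000 nM in this assay, at which 1 of the 3 values shown sits, and therefore says little. Compound 3 `CN(C)CCCCOC(=O)Nc1ccc(Cn2nc(-c3cncnc3)c3ccccc3c2=O)cc1` is a further variant of the same core, and in this assay compound 3 gives 65300 nM, which is the lower of the two actual numbers, though compound 2 stands nearest to it and within the scatter.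

Compound 4 `COc1cccc(-c2nn(Cc3ccc(NC(=O)OCCCCN(C)C)cc3)c(=O)c3ccccc23)c1` differs from compound 3 in one place: 3-methoxyphenyl in place of pyrimidin-5-yl on an aromatic carbon. Among the measured compounds shown here, no measured step touches this position; the only step recorded sits on a nitrogen on an aromatic ring and stayed within the scatter. For the measured compounds named here, nothing in the numbers so far points to a shift beyond the scatter in this assay for this change. The step from compound 3 to compound 4 is expected to be a 1.1-fold lower number from compound 3 to compound 4 (0.02 log units; within the scatter). Compound 4 is estimated at 62000 nM, between 30000 nM and 120000 nM, with a real chance that the assay returns only a limit.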

Compound 4, half-maximal cytotoxic concentration: 17600 nM
Compound 4: middle estimate off by 3.5-fold (0.55 log units), on the high side, outside the stated range (below it).
By their numbers in this assay, from the lowest: compound 4; then compounds 3 and 2 (each within the scatter of the next). At a limit, above all of these: compound 1.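

Among these compounds, this carbon of the six-membered aromatic ring with 2 nitrogen, part of a fused or bridged system of two rings, is the first place where one change moves the read-out beyond the scatter: in this assay the exchange of pyrimidin-5-yl for 3-methoxyphenyl gives a 3.7-fold lower number from compound 3 to compound 4 (0.57 log units; beyond the scatter) and so points to higher toxicity in this test. Among the compounds shown here, the one earlier step sat on a nitrogen on an aromatic ring, lay within the scatter and was bounded by a limit, so it gave no sign that a single exchange could shift this read-out, whereas the group on this carbon clearly matters here. Nothing measured in the series bears on why the number falls with this exchange.

The compounds shown do not separate the methoxy group from the change to a ring of carbon only, and a plain phenyl or a pyridin-3-yl on this carbon would be the comparison that does. Also open, on these data alone, is whether the step carries over when a morpholine stands in place of the dimethylamino group at the end of the chain.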